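A few compounds are considered here, and "the series" means these few. Any claim that something is new, unique, unknown or untested is made for them only; others in the source may bear on it.

Series notes. Compound 1 `CCN(CC)C(=O)C1=C(C)NC(=O)NC1c1ccco1` and compound 2 `CCC(CC)OC(=O)C1=C(C)NC(=O)NC1c1ccco1` share a core and differ only in the group on a carbonyl carbon. Among the measured compounds shown here, in an assay on membranes from HeLa cells for displacement of a labelled ligand from adenosine receptor A3 (Homo sapiens), read by scintillation counting, with a stated time of 180 min, tested at 1 uM (on this read-out higher numbers stand for more inhibition at the one concentration tested (going by the name of the read-out) and lower numbers for less inhibition), compound 1 gives 19%, and compound 2 gives 1%; the step of a number 18 percentage points lower from compound 1 to compound 2 (beyond the scatter) is the one measured change, (pentan-3-yl)oxy in place of diethylamino, and it lies beyond the scatter. For the measured compounds named here, compound 2 therefore stands at the lower of the two numbers so far.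

Compound 3 `CC1=C(C(=O)OCC2CC2)C(c2ccco2)NC(=O)N1` is not yet measured. It differs from compound 2 by cyclopropylmethyl in place of pentan-3-yl on an oxygen next to a carbonyl group. Going by the values given here, no measured step bears directly on this change: the only step known alters the carbonyl substituent from an amine to an ester oxygen, whereas here the ester is kept and only the alkyl group on the oxygen is exchanged. With compound 2 already at the bottom of the measured range, the expected step of a number 2 percentage points higher from compound 2 to compound 3 (within the scatter) for compound 3 is none beyond the scatter. Compound 3 is estimated at 3%, within a range of -8% to 14%.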

Compound 3, a percentage reported as inhibition, at one concentration (the size of the read-out at that concentration, not a potency): 1%
Compound 3: middle estimate off by 2 percentage points, on the high side, and the stated range covers the measured number.
By their numbers in this assay, from the lowest: compounds 2 and 3 (each within the scatter of the next); then compound 1.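

In this assay, cyclopropylmethyl in place of pentan-3-yl on an oxygen next to a carbonyl group gives no change at the digits printed from compound 2 to compound 3 (within the scatter), so this position now has a second alkyl group to read, and a three-membered ring there does not separate from the open chain. Against the diethylamino group on the carbonyl carbon, cyclopropylmethoxy gives a number 18 percentage points lower from compound 1 to compound 3 (beyond the scatter), a gap of the same size as the one printed for (pentan-3-yl)oxy, so compound 2 and compound 3 both stand apart from compound 1. Nothing at hand accounts for these numbers.

Going by these compounds, whether the higher number of compound 1 extends to other amines on the carbonyl carbon stays open, and dimethylamino or pyrrolidine there would speak to it. Among the compounds shown here, a benzyl group or a longer chain on the oxygen would show whether any ester rises above the two read so far.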